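Fluoro in Place of Methyl: From Compound 1 to Compound 4

The compounds below may be only part of what the source reports. "The series", "measured", "known", "first", "only" and "open" are said of these compounds alone.

Measured compounds:
- compound 1 `Cc1cnc(N2CCC(c3coc4c(N5CCc6cc(S(C)(=O)=O)ccc65)ncnc34)CC2)nc1`: 252 nM
- compound 2 `CC(C)(C)OC(=O)N1CCC(c2noc3c(Nc4ccc(S(C)(=O)=O)cc4F)ncnc23)CC1`: 353 nM
- compound 3 `CC(C)(C)OC(=O)N1CCC(c2c[nH]c3c(Nc4ccc(S(C)(=O)=O)cc4F)ncnc23)CC1`: a limit of > 1000 nM

Three compounds have been run in a functional assay on cells for agonist activity at Glucose-dependent insulinotropic receptor (Homo sapiens), read by a luciferase reporter, with a stated time of 4 h; a lower number here means that less compound is needed, a higher number that more compound is needed for the effect. Compound 1 gives 252 nM, the lowest of the two numbers reported. Compound 2 gives 353 nM, and the gap to compound 1 lies within the scatter, so the two cannot be ranked. For compound 3 the assay reports only a limit, > 1000 nM, which is the limit of > 1000 nM in this assay, at which 1 of the 3 values shown sits.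

Compound 4 `CS(=O)(=O)c1ccc2c(c1)CCN2c1ncnc2c(C3CCN(c4ncc(F)cn4)CC3)coc12` has not yet been measured. It differs from compound 1 in one place: fluoro in place of methyl on an aromatic carbon, that is, 5-methylpyrimidin-2-yl becomes 5-fluoropyrimidin-2-yl. For the measured compounds named here, no pair of measured compounds shows this particular change, so there is no measured step to lean on. A swap of one small group for another of the same size, with no change in donors, acceptors or charge, is expected to shift the number little, if at all, beyond the scatter in this assay. Compound 4 is therefore expected to come out near compound 1, at an estimated 250 nM, with a likely range from 100 nM to 600 nM. This estimate means a step of a 1.0-fold lower number from compound 1 to compound 4 (0.00 log units; within the scatter), which is expected to sit within the scatter.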

Compound 4, half-maximal effective concentration: 201 nM
Compound 4: middle estimate off by 1.2-fold (0.09 log units), on the high side; the measured number falls inside the stated range.
By their numbers in this assay, from the lowest: compounds 4, 1 and 2 (each within the scatter of the next). At a limit, above all of these: compound 3.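

In this assay, for the compounds shown here, the swap of 5-methylpyrimidin-2-yl for 5-fluoropyrimidin-2-yl is the first change at a single place that can be read, and it amounts to a 1.3-fold lower number from compound 1 to compound 4 (0.10 log units; within the scatter) and so leaves the two compounds indistinguishable. This position on the six-membered aromatic ring, para to a large group, therefore accepts fluoro as well as methyl without a measurable difference in the number. Nothing measured here explains why the two groups read alike.

The compounds shown leave open whether a methoxy group, a nitrile or a carboxylic acid at this position would keep the number where it is or move it. They also do not show what plain hydrogen there would give, which would tell whether any group is needed at this position at all.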